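Removing the chloro group from compound 1

The compounds below may be only part of what the source reports. "The series", "measured", "known", "first", "only" and "open" are said of these compounds alone.

Measured so far:
compound 1 `CNC(=O)c1cc(C(=O)N[C@H]2CC[C@H](O)CC2)c([C@@H](C)c2cccc(Cl)c2)o1`: 62%
compound 2 `CNC(=O)c1cc(C(=O)N[C@H]2CC[C@H](OC)CC2)n([C@@H](C)c2ccccc2)n1`: 95%

In an ADME assay on the whole organism (Canis lupus familiaris, strain Beagle) for pharmacokinetics, read by LC-MS, with a stated time of 7 h, at a dose of 1 mg/kg by the oral route (a lower number here means that a smaller share of the oral dose reaches the circulation, a higher number that a larger share of the oral dose reaches the circulation), compound 1 stands lowest of the two measured compounds, and the gap up to compound 2 lies beyond the usual scatter. Going by the values given here, no two measured compounds differ in one place only, so no measured step bears directly on the change below.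

Compound 3 `CNC(=O)c1cc(C(=O)N[C@H]2CC[C@H](O)CC2)c([C@@H](C)c2ccccc2)o1` is not yet measured. It carries hydrogen in place of chloro on an aromatic carbon, so 3-chlorophenyl becomes phenyl: hydrogen in place of chloro on an aromatic carbon. Among the compounds with values here, the only guide is weak: compound 2, also a phenyl compound, gives 95% but differs from compound 1 elsewhere too. The expected step of a number 6 percentage points higher from compound 1 to compound 3 (within the scatter) is small and upward, probably within the scatter. For compound 3 the estimated value is 68%, with an expected range from 45% to 90%.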

Compound 3, oral bioavailability: 84%
Estimate against measurement, compound 3: 16 percentage points below; low and high end bracket the measured number.
By their numbers in this assay, from the lowest: compound 1; then compound 3; then compound 2.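

In this assay, going by these compounds alone, hydrogen in place of chloro on an aromatic carbon gives a number 22 percentage points higher from compound 1 to compound 3 (beyond the scatter) and this is the only change that can be read at a single place. So at this position of the 1-phenylethyl group, on the core of compound 1, the chloro group is not needed for a large share of the oral dose to reach the circulation, and 3-chlorophenyl reads lower than phenyl. Nothing at hand gives a reason for this step.

From the compounds shown here alone, whether the step belongs to chloro alone stays open: fluoro, methyl or nitrile at the same place could fall on either side of compound 3. Going by these compounds, whether the step would carry over to the core of compound 2 also stays open.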